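Dropping the methoxy group from compound 2

The source may report more compounds than this note shows. Statements on the series, on what has been measured and on what is new or still open speak of the compounds shown alone.

Compound 1, `Cc1ccc([C@]2(CO)NC[C@@H](O)[C@@H]2O)cc1`, gives 43000 nM in an assay on isolated protein for inhibition of lysosomal alpha-glucosidase (Rattus norvegicus), read by colorimetric assay; on this read-out lower numbers stand for stronger inhibition and higher numbers for weaker inhibition.
Compound 2, `COc1ccc([C@]2(CO)NC[C@@H](O)[C@@H]2O)cc1`, gives 395000 nM.
Compound 3, `COc1ccc([C@@]2(CO)NC[C@H](O)[C@H]2O)cc1`, gives 2100 nM.

Compound 2 gives the highest number of the three and is thus the weakest inhibitor here. Compound 4, `OC[C@@]1(c2ccccc2)NC[C@@H](O)[C@@H]1O`, differs from compound 2 by hydrogen in place of methoxy on an aromatic carbon. Going by the values given here, one measured step bears on this: a 9.2-fold higher number from compound 1 to compound 2 (0.96 log units; beyond the scatter), where a methyl rather than a hydrogen stood in for the methoxy. The step of a 190-fold lower number from compound 2 to compound 3 (2.27 log units; beyond the scatter) concerns only configuration and says nothing about a change of substituent. Removing the methoxy is therefore expected to lower the number modestly, roughly undoing that first step. Compound 4 is estimated at 80000 nM, within 20000 nM to 320000 nM. The expected step is a 4.9-fold lower number from compound 2 to compound 4 (0.69 log units; beyond the scatter).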

Compound 4, half-maximal inhibitory concentration: 904000 nM
The estimate for compound 4 lay 11-fold (1.05 log units) below the measured number; measured number outside the range, above it.
By their numbers in this assay, from the lowest: compound 3; then compound 1; then compound 2; then compound 4.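

Hydrogen in place of methoxy raises the number rather than lowering it (a 2.3-fold higher number from compound 2 to compound 4 (0.36 log units; beyond the scatter)), and the rise is larger against methyl (a 21-fold higher number from compound 1 to compound 4 (1.32 log units; beyond the scatter)). So at this place on the ring, both groups give lower numbers than hydrogen does, and methoxy is not the drawback that compound 1 alone suggested. Nothing at hand explains this order.

On these data alone, whether a chlorine atom, an amine or a longer chain would go lower than methyl stays open. So does whether the same order holds with the inverted configuration of compound 3.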